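Thiophen-2-yl in place of methylcarbamoyl: working notes

The source may hold more compounds than are shown below. What is called first, only, known or untested is meant among the compounds shown, and "the series" means these compounds.

Measured so far in a physicochemical assay for solubility, in phosphate buffer, at pH 7.4; on this read-out lower numbers stand for lower solubility and higher numbers for higher solubility (values below)
- Compound 1 `CNC(=O)CN1CCC(c2cc3c(-c4ccc(=O)n(C(C)C)c4)ccnc3[nH]2)CC1` gives 34000 nM
- Compound 2 `COc1cc(C(=O)N2CCCC2)ccc1-c1ccnc2[nH]c(C3CCOCC3)cc12` gives 15000 nM

Compound 1 stands highest of these two numbers, and compound 2 lies lower by more than the usual scatter. The next compound to be read is compound 3 `CC(C)n1cc(-c2ccnc3[nH]c(C4CCN(Cc5cccs5)CC4)cc23)ccc1=O`, still unmeasured. It carries thiophen-2-yl in place of methylcarbamoyl on a saturated chain carbon bound to an amine nitrogen in a ring (counted difference (thiophen-2-yl in place of methylcarbamoyl on a saturated chain carbon bound to an amine nitrogen in a ring)), so (methylcarbamoyl)methyl becomes (thiophen-2-yl)methyl. For the measured compounds named here, no measured pair differs in one place only, so nothing measured sizes this change directly. In this assay a step downward beyond the scatter is expected, as a judgement from the structural change alone. The estimated size is a 4.9-fold lower number from compound 1 to compound 3 (0.69 log units; beyond the scatter) and awaits measurement. For compound 3 the expected value is 7000 nM (estimated range 1500 nM to 25000 nM).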

Compound 3, solubility: 25000 nM
The estimate for compound 3 lay 3.6-fold (0.55 log units) below the measured number; low and high end bracket the measured number.
By their numbers in this assay, from the lowest: compounds 2, 3 and 1 (each within the scatter of the next, the first and the last beyond it).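

In this assay, the change to thiophen-2-yl in place of methylcarbamoyl on a saturated chain carbon bound to an amine nitrogen in a ring reads a 1.4-fold lower number from compound 1 to compound 3 (0.13 log units; within the scatter) and is the only step shown that sizes a change in one place. At this position, a group with no ring and 1 hydrogen-bond donor can therefore give way to a five-membered aromatic ring with 0 hydrogen-bond donors, with the two numbers remaining within the scatter of each other. Nothing at hand accounts for this outcome.

Going by these compounds, whether a carboxylic acid, a phenyl ring or a longer chain at the same place would also stay within the scatter remains open, since one step cannot establish a trend at this position. Compound 2 differs from compound 1 and compound 3 in more than one place and sizes nothing here.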